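The compounds below may be only part of what the source reports. "The series", "measured", "known", "first", "only" and "open" are said of these compounds alone.

Measured compounds:
- compound 1 `COc1ccc(CNCCCNS(=O)(=O)c2cc(C(F)(F)F)cc(C(F)(F)F)c2)cc1OC`; in a functional assay on MCF7 cells (Homo sapiens) for inhibition, read by MTT assay, with a stated time of 72 h (a lower number here means a stronger inhibitor of growth, a higher number a weaker inhibitor of growth), compound 1 gives 1900 nM
- compound 2 `O=S(=O)(NCCCNCC1COc2ccccc2O1)c1cc(C(F)(F)F)cc(C(F)(F)F)c1`; in this assay compound 2 gives 2500 nM
- compound 3 `O=S(=O)(NCCCNCc1ccccc1Cl)c1cc(C(F)(F)F)cc(C(F)(F)F)c1`; in this assay compound 3 gives 8800 nM

Compound 3 stands highest of the three, so it is the weakest growth inhibitor here: a 4.6-fold higher number from compound 1 to compound 3 (0.67 log units; beyond the scatter) and a 3.5-fold higher number from compound 2 to compound 3 (0.55 log units; beyond the scatter). Compound 4 `O=S(=O)(NCCCNCc1ccccc1)c1cc(C(F)(F)F)cc(C(F)(F)F)c1` differs from compound 3 in one place: hydrogen in place of chloro on an aromatic carbon. Among the measured compounds shown here, no measured step removes this chloro; the two steps that exist swap the whole aryl group and are modest in size, so changes at this position can move the number, though the direction for compound 4 is uncertain. A modest step in this assay is therefore plausible, with a wide range. Compound 4 is expected at 6000 nM, between 2500 nM and 15000 nM, meaning an estimated 1.5-fold lower number from compound 3 to compound 4 (0.17 log units; within the scatter).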

Compound 4, concentration for 50% growth inhibition: 3000 nM
For compound 4 the middle estimate is 2.0-fold (0.30 log units) above the measured one, within the range that was stated.
By their numbers in this assay, from the lowest: compounds 1, 2 and 4 (each within the scatter of the next); then compound 3.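

In this assay, the loss of the chloro alone gives a 2.9-fold lower number from compound 3 to compound 4 (0.47 log units; beyond the scatter) and is enough to bring a compound back among the others. The plain phenyl group matches the larger aryl groups, with a 1.2-fold higher number from compound 2 to compound 4 (0.08 log units; within the scatter) and a 1.6-fold higher number from compound 1 to compound 4 (0.20 log units; within the scatter), so neither the 3,4-dimethoxyphenyl nor the 2,3-dihydro-1,4-benzodioxin-2-yl group shows any gain over it. Nothing available explains the effect of the chloro. On these data alone, whether a fluoro or a methyl on that same aromatic carbon would match hydrogen or chloro remains open.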